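A few compounds are considered here, and "the series" means these few. Any claim that something is new, unique, unknown or untested is made for them only; others in the source may bear on it.

Compound 1 `O=C(O)c1ccccc1-c1ccc(CCc2ncc(CC3CCCC3)[nH]2)cc1` gives 7.9 nM in an in vitro functional assay on cells for agonist activity at Bombesin receptor subtype-3 (Mus musculus), read by luminescence and calcium flux; on this read-out lower numbers stand for an effect already at smaller amounts and higher numbers for an effect only at larger amounts of compound.
Compound 2 `O=C(O)c1ccccc1-c1ccc(CCc2ncc(Cc3ccc(Cl)cc3)[nH]2)cc1` gives 102 nM in this assay.
Compound 3 `CCCCc1cnc(CCc2ccc(-c3ccccc3C(=O)O)cc2)[nH]1` gives 93 nM in this assay.

Compound 3 stands among the two higher numbers of the three, within the scatter of compound 2 and far from compound 1, whose number is much lower. The step to compound 4 `CC(C)(C)CCc1cnc(CCc2ccc(-c3ccccc3C(=O)O)cc2)[nH]1` is tert-butyl in place of ethyl on a saturated chain carbon, two bonds along the chain from an aromatic carbon, so the chain at this end grows and branches. The measured steps at this chain end bear on it: a 12-fold higher number from compound 1 to compound 3 (1.07 log units; beyond the scatter) shows that a bulkier, ring-bearing end gives a far lower number, while a 1.1-fold lower number from compound 2 to compound 3 (0.04 log units; within the scatter) shows that swapping a chlorophenyl end for a propyl end changes nothing beyond the scatter. Among the compounds with values here, no measured compound carries a tert-butyl at this place, so the weight rests on compound 1, with its 7.9 nM. A lower number is therefore expected, a 3.1-fold lower number from compound 3 to compound 4 (0.49 log units; beyond the scatter), though smaller than the gain seen in compound 1. Compound 4 is expected to give about 30 nM in this assay, with a range from 8 nM to 110 nM.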

Compound 4, half-maximal effective concentration: 6.2 nM
Compound 4: middle estimate off by 4.8-fold (0.68 log units), on the high side; the measured number lies below the stated range.
By their numbers in this assay, from the lowest: compounds 4 and 1 (each within the scatter of the next); then compounds 3 and 2 (each within the scatter of the next).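

In this assay tert-butyl in place of ethyl, on a saturated chain carbon two bonds along the chain from an aromatic carbon, gives a 15-fold lower number from compound 3 to compound 4 (1.18 log units; beyond the scatter) and so shows that this end needs no ring to reach a low number. Within the data shown here, the earlier compounds could not show this, as their only low number belonged to the cyclopentyl end of compound 1, and the open-chain neopentyl end now stands level with it, at a 1.3-fold lower number from compound 1 to compound 4 (0.11 log units; within the scatter) and so within the scatter. Nor does a ring alone decide the outcome, since neopentyl in place of 4-chlorophenyl gives a 16-fold lower number from compound 2 to compound 4 (1.22 log units; beyond the scatter) and the ring-bearing compound 2 lies within the scatter of the open-chain compound 3.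

On these data alone, whether a longer chain, or an amine or a carboxylic acid at the end of this chain, would keep such a low number remains open. No evidence at hand accounts for any of these steps.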